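This account rests on a few compounds, and the source may have more. Where it says the series, first, only, none or still open, it means among the compounds named here.

Three compounds have numbers in a toxicity assay on cells (Macrophage, Mus musculus, strain BALB/c) for cytotoxicity, read by MTT assay; a higher number here means a weaker inhibitor, a lower number a stronger inhibitor. Compound 1 `C=CCOc1cc(OC)c(C(=O)/C=C/Cc2ccccc2)c(OCC=C)c1` gives 14800 nM in this assay, compound 2 `C=CCOc1cc(OC)c(C(=O)/C=C/c2ccc(F)cc2)c(OCC=C)c1` gives 13800 nM, and compound 3 `COc1cc(O)cc(O)c1C(=O)/C=C/c1ccc(C)cc1` gives 16500 nM. Within the data shown here, the only single-point step among the measured compounds is a 1.1-fold lower number from compound 1 to compound 2 (0.03 log units; within the scatter). Compound 3 sits together with compound 1 and compound 2: the gaps between its value and theirs are within the scatter, so the three cannot be told apart in this assay.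

Compound 4 `COc1cc(O)cc(O)c1C(=O)/C=C/c1ccc(O)cc1` is not yet measured. It differs from compound 3 by hydroxy in place of methyl on an aromatic carbon. Among the measured compounds shown here, no measured step exchanges a methyl for a hydroxy, and the one step available concerns a different part of the molecule and stayed within the scatter, so nothing among the measured compounds speaks for a shift in either direction here. The expectation for compound 4 is therefore a step of a 1.1-fold higher number from compound 3 to compound 4 (0.04 log units; within the scatter), within the scatter. Compound 4 is estimated at 18000 nM, with a range of 8000 nM to 40000 nM.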

Compound 4, half-maximal inhibitory concentration: 21700 nM
Beside the measured number, compound 4's estimate is 1.2-fold (0.08 log units) below it, and the stated range covers the measured number.
By their numbers in this assay, from the lowest: compounds 2, 1, 3 and 4 (each within the scatter of the next).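

In this assay, hydroxy in place of methyl on an aromatic carbon, para to a large group, gives a 1.3-fold higher number from compound 3 to compound 4 (0.12 log units; within the scatter), so 4-methylphenyl and 4-hydroxyphenyl cannot be told apart here. The change adds a hydrogen-bond donor and a hydrogen-bond acceptor at this position, and the number still shows no shift beyond the scatter. Among these compounds, the earlier step concerned benzyl and 4-fluorophenyl on the chain in a different setting, so this is the first direct reading at this position on the core of compound 3.

Going by these compounds, whether an amine, a carboxylic acid or a longer chain at this position would move the number beyond the scatter remains open. No measurement at hand bears on what lies behind the size of this step.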